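A few compounds are considered here, and "the series" means these few. Any claim that something is new, unique, unknown or untested is made for them only; others in the source may bear on it.

In a functional assay on cardiac atrium for agonist activity at histamine H2 receptor (Cavia porcellus) (on this read-out higher numbers stand for higher potency (the scale is a negative logarithm) and lower numbers for lower potency), compound 1 `N=C(NCCCc1c[nH]cn1)NCCC(c1ccccc1)c1ccccn1` gives 7.39. Compound 2 `N=C(NCCCc1c[nH]cn1)NCCC(c1ccc(Br)cc1)c1ccccn1` gives 7.48 in this assay; the step of a number 0.09 log units higher from compound 1 to compound 2 (within the scatter) lies within the scatter. Compound 3 `CN/C(=N\CCC(c1ccc(Br)cc1)c1ccccn1)NCCCc1c[nH]cn1`, which differs from compound 2 at the guanidine nitrogen, is measured too: in this assay compound 3 gives 5.75. Among the three numbers, compound 2 holds the highest, though its margin over compound 1 is within the scatter, while the gap of compound 3 lies beyond it.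

Compound 4 `N=C(NCCCc1c[nH]cn1)NCCC(c1ccc(Cl)c(Cl)c1)c1ccccn1` has not yet been measured. It differs from compound 2 by 3,4-dichlorophenyl in place of 4-bromophenyl on a saturated chain carbon bound to an aromatic carbon and a saturated chain carbon. Going by the values given here, the only step that bears on this change is the exchange of a substituent on the same aromatic ring, a number 0.09 log units higher from compound 1 to compound 2 (within the scatter), which is within the scatter. Compound 4 is therefore expected to stay close to compound 2, with a step of a number 0.08 log units lower from compound 2 to compound 4 (within the scatter) that is not expected to exceed the scatter. The estimate for compound 4 in this assay is 7.4, with a range from 6.9 to 7.9.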

Compound 4, negative logarithm of the half-maximal effective concentration: 8.19
Estimate against measurement, compound 4: 0.79 log units below; measured number outside the range, above it.
By their numbers in this assay, from the lowest: compound 3; then compounds 1 and 2 (each within the scatter of the next); then compound 4.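

The aryl group on the saturated chain carbon had so far shown no step beyond the scatter, since bromo in place of hydrogen on the phenyl ring of compound 1 left the number in this assay within it. The exchange for 3,4-dichlorophenyl shows that this position can respond: 3,4-dichlorophenyl in place of 4-bromophenyl gives a number 0.71 log units higher from compound 2 to compound 4 (beyond the scatter) and in place of phenyl gives a number 0.80 log units higher from compound 1 to compound 4 (beyond the scatter) in the same assay, so a change on this ring can raise the number even though the single bromo did not. Nothing given here explains why the 3,4-dichlorophenyl group differs from the 4-bromophenyl group.

From the compounds shown here alone, it remains open whether a single chlorine, as in 4-chlorophenyl or 3-chlorophenyl, would carry the same step or whether both chlorines are needed. Also open, going by these compounds, is whether 3,4-difluorophenyl or 3,4-dimethylphenyl at this place would behave like 3,4-dichlorophenyl.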